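The compounds below may be only part of what the source reports. "The series", "measured", "known", "first", "only" and "open" are said of these compounds alone.

Working notes on the series in a functional assay on HeLa cells (Homo sapiens) for antiproliferative activity, read by CCK-8 assay, with a stated time of 72 h, tested at 8 uM; a higher number here means a stronger effect of the compound at the concentration tested, a lower number a weaker effect.

Compound 1 `CC1CCN(C(=S)SCc2ccc(C(=O)Nc3ccccc3N)cc2)CC1` gives 72.5%. Going by the values given here, compound 2 `CN(Cc1cccnc1)C(=S)SCc1ccc(C(=O)Nc2ccccc2N)cc1` gives 68.7%; the one step that changes a single place, a number 3.8 percentage points lower from compound 1 to compound 2 (within the scatter), is therefore flat. Compound 3 `Nc1ccccc1NC(=O)c1ccc(CSC(=S)N2CCN(c3ccncc3)CC2)cc1` gives 77.4%, the largest of the three numbers as they stand, though its gap to compound 1 and its gap to compound 2 both lie within the scatter, so no ordering among the three is supported.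

Compound 4 `N#Cc1ccc(N2CCN(C(=S)SCc3ccc(C(=O)Nc4ccccc4N)cc3)CC2)cc1` is the next step from compound 3: 4-cyanophenyl in place of pyridin-4-yl on an amine nitrogen in a ring. Among the compounds with values here, the only measured step, the replacement on the thiocarbonyl carbon from compound 1 to compound 2, touches the same side of the shared core but swaps a different part, and it stayed within the scatter. Nothing measured here speaks for a step beyond the scatter in this assay in either direction, and the three numbers sit close together. The step from compound 3 to compound 4 is expected to be a number 3.4 percentage points lower from compound 3 to compound 4 (within the scatter). Compound 4 is estimated to give 74%, with a range from 62% to 86%.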

Compound 4, a percentage reported as inhibition, at one concentration (the size of the read-out at that concentration, not a potency): 70.6%
Beside the measured number, compound 4's estimate is 3.4 percentage points above it; the measured number falls inside the stated range.
By their numbers in this assay, from the lowest: compounds 2, 4, 1 and 3 (each within the scatter of the next).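

On the amine nitrogen of the six-membered non-aromatic ring with 2 nitrogen, 4-cyanophenyl in place of pyridin-4-yl gives a number 6.8 percentage points lower from compound 3 to compound 4 (within the scatter) in this assay. Going by these compounds alone, this is the first step read at this place, and it shows that an aromatic ring of carbon only, carrying a nitrile, can replace the pyridine-type ring without a step beyond the scatter, while the larger group adds no measurable change in this read-out. Nothing measured on these compounds explains this flat result.

As far as these compounds go, what a plain phenyl, a carboxylic acid or an aliphatic amine at this place would give remains open, including whether any group here moves the number beyond the scatter. Also open, from the compounds shown here alone, is how these single-concentration read-outs relate to potency, since all the numbers sit close together.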